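The source may hold more compounds than are shown below. What is called first, only, known or untested is meant among the compounds shown, and "the series" means these compounds.

Compound 1 `Cc1ccc(C(=O)NC2CCCCCC2)c(=O)n1Cc1ccc(F)cc1` is the parent of the series. In an assay on HEK293 cells for inhibition of Monoacylglycerol lipase ABHD6 (Homo sapiens), read by scintillation counting, with stated times of 30 min and 5 min (on this read-out lower numbers stand for stronger inhibition and higher numbers for weaker inhibition), compound 1 gives > 10000 nM, which is a limit of the assay rather than a number. Compound 2 `Cc1c(-c2ccc(F)cc2)cc(C(=O)NC2CCCCCC2)c(=O)n1Cc1ccc(F)cc1` carries the 4-fluorophenyl group. In this assay compound 2 gives > 10000 nM, again only a limit. The step that the two limits leave unreadable from compound 1 to compound 2 therefore cannot be sized, because both values sit at the limit of > 10000 nM in this assay, at which 2 of the 2 values shown sit. Among the compounds with values here, compound 2 thus stands only at the limit in this assay, and the one further value shown is a limit as well; nothing so far has reached a measurable number.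

Compound 3 `Cc1c(Br)cc(C(=O)NC2CCCCCC2)c(=O)n1Cc1ccc(F)cc1` is the next member. It differs from compound 2 by bromo in place of 4-fluorophenyl on an aromatic carbon. Within the data shown here, the only measured step that bears on this place, a step that the two limits leave unreadable from compound 1 to compound 2, is unreadable, so neither a direction nor a size can be drawn from it. With no readable step to lean on, the expected step that the limit leaves unreadable from compound 2 to compound 3 is taken as none beyond the scatter. Compound 3 is estimated at 15000 nM in this assay, with a range from 4000 nM to 60000 nM, and is most likely to be reported only as a limit.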

Compound 3, half-maximal inhibitory concentration: > 10000 nM
Compound 3 was reported as a limit (the forecaster's own chance of this, stated with the estimate: 80%); the middle value lies beyond the limit too.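

No step can be read among compound 1, compound 2 and compound 3 in this assay, because each of the three is reported only as a limit and not as a number: the limit of > 10000 nM in this assay, at which 3 of the 3 values shown sit.

The compounds shown leave open whether hydrogen, bromo or 4-fluorophenyl on this aromatic carbon differ at all in inhibition, and what change to the shared core would give a measurable value.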